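A few compounds are considered here, and "the series" means these few. Any claim that something is new, unique, unknown or untested is made for them only; others in the source may bear on it.

Compound 1 `O=c1[nH]cc(S(=O)(=O)Nc2ccccc2-c2cn(-c3ccccc3)nn2)c(=O)[nH]1` is the reference of the set; in an ADME assay on L02 cells (Homo sapiens) for cytotoxicity, read by MTT assay, with a stated time of 24 h (a lower number here means that less compound is tolerated, a higher number that more compound is tolerated), compound 1 gives 10600 nM. Compound 2 `Cc1ccc(-n2cc(-c3ccccc3NS(=O)(=O)c3c[nH]c(=O)[nH]c3=O)nn2)cc1` carries methyl in place of hydrogen on an aromatic carbon. In this assay compound 2 reaches only the assay limit, > 100000 nM. Going by the values given here, the measured step of an at least 9.4-fold higher number from compound 1 to compound 2 (0.97 log units; beyond the scatter) is the single step in hand, and it ends at the limit of > 100000 nM in this assay, at which 2 of the 3 values shown sit. Compound 3 `O=c1[nH]cc(S(=O)(=O)Nc2cccc(-c3cn(-c4ccccc4)nn3)c2)c(=O)[nH]1` in this assay likewise stops at the limit, > 100000 nM. Compound 3 therefore stands with compound 2 at the limit, with no number of its own. Compound 4 `O=c1[nH]cc(S(=O)(=O)Nc2cccc(-c3cn(-c4ccccc4F)nn3)c2)c(=O)[nH]1` differs from compound 3 by fluoro in place of hydrogen on an aromatic carbon. Among the compounds with values here, no measured step covers this change; the one step known, an at least 9.4-fold higher number from compound 1 to compound 2 (0.97 log units; beyond the scatter), moved a compound onto the limit. A value again at or past the limit is expected for compound 4 in this assay, with no step beyond the scatter. Compound 4 is estimated at 120000 nM, between 40000 nM and 400000 nM, which means an expected step that the limit leaves unreadable from compound 3 to compound 4.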

Compound 4, half-maximal cytotoxic concentration: "not toxic" (no number reported)
Compound 4 has no reported number here; the estimate stays without a comparison.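

No step can be read from compound 3 to compound 4, since compound 4 is reported only as "not toxic", without a number. The compounds shown leave open what phenyl to 2-fluorophenyl changes in this assay.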